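Para-fluoro on the benzyl amide: from compound 2 to compound 3

The source may hold more compounds than are shown below. What is called first, only, known or untested is meant among the compounds shown, and "the series" means these compounds.

Compounds measured so far in a functional assay on HepG2 cells (Homo sapiens) for antiproliferative activity, read by CCK-8 assay, with a stated time of 48 h; a higher number here means a weaker inhibitor, a lower number a stronger inhibitor:
- compound 1, `O=C(Nc1ccc(Cl)cc1)c1cc(Oc2ccc(/C=C/c3ccncc3)cc2)ccn1`, gives 56200 nM
- compound 2, `O=C(NCc1ccccc1)c1cc(Oc2ccc(/C=C/c3ccncc3)cc2)ccn1`, gives 28900 nM

Within the data shown here, compound 2 stands at the lowest of the two numbers in this assay, but its only neighbour, compound 1, sits within the scatter of it: a 1.9-fold lower number from compound 1 to compound 2 (0.29 log units; within the scatter). Compound 3, `O=C(NCc1ccc(F)cc1)c1cc(Oc2ccc(/C=C/c3ccncc3)cc2)ccn1`, has not yet been measured. It differs from compound 2 by fluoro in place of hydrogen on an aromatic carbon, the benzyl becoming a 4-fluorobenzyl. Among the measured compounds shown here, no measured step in this set concerns a fluoro in place of hydrogen; the one step known, from a 4-chlorophenyl to a benzyl amide, stayed within the scatter. With nothing in the data pointing either way, compound 3 is expected to stay close to compound 2, with a step of a 1.2-fold lower number from compound 2 to compound 3 (0.06 log units; within the scatter) that lies within the scatter. Compound 3 is therefore estimated at 25000 nM in this assay, with a range from 10000 nM to 60000 nM.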

Compound 3, half-maximal inhibitory concentration: 37200 nM
Compound 3: middle estimate off by 1.5-fold (0.17 log units), on the low side; the range from low to high includes it.
By their numbers in this assay, from the lowest: compounds 2, 3 and 1 (each within the scatter of the next).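

In this assay, fluoro in place of hydrogen on the benzyl amide gives a 1.3-fold higher number from compound 2 to compound 3 (0.11 log units; within the scatter), so this first change on the benzyl group itself leaves the number within the scatter. Replacing the whole amide substituent, with 4-fluorobenzyl in place of 4-chlorophenyl, gives a 1.5-fold lower number from compound 1 to compound 3 (0.18 log units; within the scatter), which is also within the scatter, so the three amides shown cannot be ranked against one another. Nothing shown here speaks to why these steps are small.

The compounds shown leave open whether a different group at this place, such as a methoxy, a trifluoromethyl, an amine or a carboxylic acid, would move the number beyond the scatter. They also leave open whether a longer chain between the amide nitrogen and the aromatic group would do so.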